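Shrinking the ether substituent of compound 1

A few compounds are considered here, and "the series" means these few. Any claim that something is new, unique, unknown or untested is made for them only; others in the source may bear on it.

Compound 1 `Cc1nn(-c2ncnc3nc[nH]c23)c2c1C(OCc1ccccc1C#N)CC(=O)N2` carries a (2-cyanobenzyl)oxy group on a saturated ring carbon of the shared core. In a functional assay on HEK293 cells for agonist activity at G-protein coupled receptor 39 (Homo sapiens), read by scintillation proximity assay and inositol phosphate accumulation, with a stated time of 75 min (a lower number here means that less compound is needed, a higher number that more compound is needed for the effect), compound 1 gives 127 nM, the lowest of the three numbers recorded. Compound 2 `Cc1nn(-c2ncnc3nc[nH]c23)c2c1C(c1ccc(OC(C)C)cc1)CC(=O)N2` gives 2700 nM, and compound 3 `Cc1nn(-c2ncnc3nc[nH]c23)c2c1C(C(=O)N(C)c1ccccc1)CC(=O)N2` gives 5220 nM. Both steps away from compound 1 are large: a 21-fold higher number from compound 1 to compound 2 (1.33 log units; beyond the scatter), and a 41-fold higher number from compound 1 to compound 3 (1.61 log units; beyond the scatter), while the pair of compound 2 and compound 3 sits closer, a 1.9-fold higher number from compound 2 to compound 3 (0.29 log units; within the scatter).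

Compound 4 `Cc1nn(-c2ncnc3nc[nH]c23)c2c1C(OCC(C)C)CC(=O)N2` keeps the ether oxygen of compound 1 but changes what hangs on it: isopropyl in place of 2-cyanophenyl on a saturated chain carbon bound to an oxygen on a saturated carbon. Within the data shown here, no measured step trims this group while keeping the oxygen; the two known steps swap the whole (2-cyanobenzyl)oxy group for 4-isopropoxyphenyl or methyl(phenyl)carbamoyl, and both raise the number by a large margin. They bear on the step to compound 4 only in showing that compound 1 loses much when this part of the molecule is altered. Removing the 2-cyanophenyl ring is therefore expected to raise the number beyond the scatter, though likely less than a full replacement did, giving a 12-fold higher number from compound 1 to compound 4 (1.07 log units; beyond the scatter) as the estimated step. Compound 4 is estimated at 1500 nM, within a range of 300 nM to 8000 nM.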

Compound 4, half-maximal effective concentration: 111 nM
Compound 4: the middle estimate sits 14-fold (1.13 log units) above what was measured; the whole stated range lies above it.
By their numbers in this assay, from the lowest: compounds 4 and 1 (each within the scatter of the next); then compounds 2 and 3 (each within the scatter of the next).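

In this assay, the 2-cyanophenyl ring proves dispensable at this place, on a saturated chain carbon bound to an oxygen on a saturated carbon: putting isopropyl in its stead gives a 1.1-fold lower number from compound 1 to compound 4 (0.06 log units; within the scatter) and so leaves the number unchanged within the scatter. The large losses seen earlier therefore do not follow from losing the ring alone, and among these four compounds the low numbers go with the two ethers, as the steps to the smaller isobutoxy group show: a 47-fold lower number from compound 3 to compound 4 (1.67 log units; beyond the scatter) and a 24-fold lower number from compound 2 to compound 4 (1.39 log units; beyond the scatter) mark the same wide gap that separated compound 1 from those two compounds. Nothing available explains why so much of the group can be exchanged at no measurable cost.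

Going by these compounds, how far the group on the oxygen can still shrink or grow remains open, as a methyl, a longer chain such as n-hexyl or a chain ending in an amine might hold the number or lose it. Also unsettled is whether the ether oxygen itself counts, a question that a plain isobutyl group on the saturated ring carbon would answer.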